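Replacing a methylphenyl arm with a nitrophenyl one

The source may report more compounds than this note shows. Statements on the series, on what has been measured and on what is new or still open speak of the compounds shown alone.

The three measured compounds share one core and differ only in the aryl group that sits next to the ring nitrogen. Compound 1 `COc1cc(-c2cc(-c3cccc4ccccc34)nc(-c3ccccc3)n2)cc(OC)c1OC` carries a naphthalen-1-yl group there; in a functional assay on HT-29 cells (Homo sapiens) for inhibition, read by MTT assay, with a stated time of 48 h (a lower number here means a stronger inhibitor, a higher number a weaker inhibitor), compound 1 gives 4730 nM. Compound 2 `COc1cc(-c2cc(-c3ccc(O)cc3)nc(-c3ccccc3)n2)cc(OC)c1OC` carries a 4-hydroxyphenyl group instead, and in this assay compound 2 gives 11300 nM, which is a 2.4-fold higher number from compound 1 to compound 2 (0.38 log units; beyond the scatter). Compound 3 `COc1cc(-c2cc(-c3ccc(C)cc3)nc(-c3ccccc3)n2)cc(OC)c1OC` carries a 4-methylphenyl group. In this assay compound 3 reaches only the limit of the measurement, > 25000 nM, so its true number is not known; it stands at the limit of > 25000 nM in this assay, at which 1 of the 3 values shown sits. That leaves an at least 5.2-fold higher number from compound 1 to compound 3 (0.72 log units; beyond the scatter) and an at least 2.2-fold higher number from compound 2 to compound 3 (0.34 log units; beyond the scatter), both beyond the scatter, placing compound 3 as the weakest of the three.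

Compound 4 `COc1cc(-c2cc(-c3cccc([N+](=O)[O-])c3)nc(-c3ccccc3)n2)cc(OC)c1OC` differs from compound 3 in one place: 3-nitrophenyl in place of 4-methylphenyl on an aromatic carbon. Among the measured compounds shown here, none of the measured steps involves a nitro group, so no measured step bears directly on this change; the steps only show that compound 3 itself is the weakest reference point. The estimate for compound 4 is therefore loosely anchored and expected to lie near the weak end of the series, with an at least 1.6-fold lower number from compound 3 to compound 4 (0.22 log units; that floor lies within the scatter) as the expected step. Compound 4 is estimated at 15000 nM, with a range from 5000 nM to 50000 nM.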

Compound 4, half-maximal inhibitory concentration: > 25000 nM
Compound 4: a limit, no number; the forecaster's own chance of this, stated with the estimate: 40%; at least 1.6-fold (0.22 log units) between middle value and limit.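

In this assay compound 4 gives > 25000 nM, which is a limit of the assay and not a number. The 3-nitrophenyl arm therefore gives no readable potency at this position and stands apart from both arms that do, with an at least 5.2-fold higher number from compound 1 to compound 4 (0.72 log units; beyond the scatter) and with an at least 2.2-fold higher number from compound 2 to compound 4 (0.34 log units; beyond the scatter) as the two readable steps. The step between compound 3 and compound 4 cannot be read, so 3-nitrophenyl and 4-methylphenyl cannot be ranked against each other, and of the four arms only naphthalen-1-yl and 4-hydroxyphenyl give a number: the limit of > 25000 nM in this assay, at which 2 of the 4 values shown sit.

The compounds shown leave open how far below or beyond that limit compound 3 and compound 4 really lie, and whether the nitro group itself or its place on the ring decides the outcome, as the two arms differ in both. They also leave open what an amine or a carboxylic acid on the same ring would give, and whether a naphthalen-2-yl arm would keep the number seen for compound 1.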